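The source may report more compounds than this note shows. Statements on the series, on what has been measured and on what is new or still open speak of the compounds shown alone.

In an ADME assay on the whole organism (plasma, strain 129/SvEvBrd x C57BL/6) for pharmacokinetics, with Mus musculus as the target, at a dose of 10 mg/kg by the oral route (a higher number here means more compound in the circulation at the dose given, a lower number less compound in the circulation), compound 1 `CC(=O)c1nc([C@@H](O)[C@H](O)[C@H](O)CO)cn1C` gives 10000 ng.h/mL, while compound 2 `CC(=O)c1nc([C@@H](O)[C@@H](O)[C@H](O)CO)c[nH]1` gives 3610 ng.h/mL, the lower of the two numbers and beyond the scatter. Compound 3 `CC(=O)c1nc([C@H](O)[C@@H](O)[C@@H](O)CO)c[nH]1` has the same atoms and bonds as compound 2 and differs only in configuration as drawn: the two compounds have the same atoms and bonds and differ only in configuration as drawn: 2 of 3 stereo elements differ; a stereocentre at a saturated chain carbon is drawn R in compound 2 and S in compound 3; a stereocentre at a saturated chain carbon is drawn R in compound 2 and S in compound 3. Within the data shown here, no measured pair here shows what such a change does in this assay, so no step beyond the scatter is expected, in either direction. The expected 1.0-fold lower number from compound 2 to compound 3 (0.00 log units; within the scatter) therefore stays within the scatter. For compound 3 the estimated value is 3600 ng.h/mL, with an expected range of 1300 ng.h/mL to 10000 ng.h/mL.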

Compound 3, area under the concentration-time curve: 4140 ng.h/mL
Beside the measured number, compound 3's estimate is 1.2-fold (0.06 log units) below it; low and high end bracket the measured number.
By their numbers in this assay, from the lowest: compounds 2 and 3 (each within the scatter of the next); then compound 1.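

Among these compounds, the pair of compound 2 and compound 3 is the first to isolate configuration in this assay: two stereocentres at saturated chain carbons are drawn R in compound 2 and S in compound 3, giving a 1.1-fold higher number from compound 2 to compound 3 (0.06 log units; within the scatter). On this chain, changing those two stereocentres together therefore produces no step beyond the scatter. The comparison is clean in one respect: the fact that compounds 2 and 3 differ only in the configuration as drawn

As far as these compounds go, the pair shows the two stereocentres only together, so the effect of either one alone remains open, as does that of the third. Also open, from the compounds shown here alone, is what an amine or a carboxylic acid on the chain would do in this assay.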